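The compounds below may be only part of what the source reports. "The series", "measured", "known", "first", "only" and "open" are said of these compounds alone.

Measured compounds in an ADME assay on isolated protein for inhibition of Amine oxidase [flavin-containing] B (Homo sapiens); a higher number here means a weaker inhibitor, a lower number a stronger inhibitor:

- compound 1, `C#CCNC1CCc2c(SCCc3cccc(C)c3)cccc21`: 4960 nM
- compound 2, `C#CCNC1CCc2c(SCc3cccc(F)c3)cccc21`: 11600 nM
- compound 3, `C#CCNC1CCc2c(SCc3ccc(Cl)c(Cl)c3)cccc21`: 74 nM

Compound 2 gives the highest number of the three in this assay, so among them it is the weakest inhibitor. Its nearest neighbour in the numbers is compound 1, whose value lies beyond the usual scatter below it; compound 3 lies far below both, with the strongest inhibition of the set.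

Compound 4, `C#CCNC1CCc2c(SCc3cccc(OC)c3)cccc21`, is not yet measured. It differs from compound 2 in one place: methoxy in place of fluoro on an aromatic carbon, on an aromatic carbon of a six-membered aromatic ring of carbon only, meta to a large group. Among the compounds with values here, no comparable exchange exists among the measured compounds, so nothing measured here tells how a methoxy and a fluoro differ at this position; the only guide is that compound 2 is already the weakest.

The expected step is estimated as a 1.7-fold lower number from compound 2 to compound 4 (0.22 log units; within the scatter), a small change with a slight lean toward a lower number. Compound 4 is therefore estimated at 7000 nM, with a plausible range from 1500 nM to 30000 nM.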

Compound 4, half-maximal inhibitory concentration: 1520 nM
Compound 4: the middle estimate sits 4.6-fold (0.66 log units) above what was measured, within the range that was stated.
By their numbers in this assay, from the lowest: compound 3; then compound 4; then compound 1; then compound 2.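

In this assay, putting methoxy in place of fluoro on the aromatic carbon meta to a large group gives a 7.6-fold lower number from compound 2 to compound 4 (0.88 log units; beyond the scatter), a step beyond the scatter. Within the data shown here, this is the first single-place exchange in the set, and it shows that the group at this position alone can move the number, with the rest of the molecule unchanged. Methoxy has more heavy atoms than fluoro and counts as a hydrogen-bond acceptor, but nothing measured here links either difference to the lower number.

One exchange cannot show whether the number would keep falling with a larger group here, such as ethoxy, or how an amine or a hydroxyl would compare. It also leaves open whether methoxy would give a similar step on a compound with a longer chain on the sulfur.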